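Phenylethynyl for Phenylethenyl on a Urotensin-2 Receptor Agonist

A few compounds are considered here, and "the series" means these few. Any claim that something is new, unique, unknown or untested is made for them only; others in the source may bear on it.

Measured so far:
compound 1 `CN(C)CCC(NC(=O)/C=C/c1ccccc1)c1ccc2ccccc2c1`: 116%
compound 2 `CN(C)CCC(NC(=O)C#Cc1ccccc1)c1ccc(Cl)cc1`: 124%
compound 3 `CN(C)CCC(NC(=O)/C=C/c1ccccc1)c1ccc(Cl)cc1`: 128%

Three amides have been tested in a functional assay on NIH3T3 cells for agonist activity at Urotensin-2 receptor (Homo sapiens), with a stated time of 5 days; on this read-out higher numbers stand for larger maximal responses and lower numbers for smaller maximal responses. Compound 3 gives 128%, compound 2 gives 124%, and compound 1 gives 116%. Compound 2 differs from compound 3 by 2-phenylethynyl in place of 2-phenylethenyl on a carbonyl carbon, and this gave a number 4 percentage points lower from compound 3 to compound 2 (within the scatter). The difference between the core of compound 1 and the core of compound 3 is not broken down here. Among the compounds with values here, compound 4 `CN(C)CCC(NC(=O)C#Cc1ccccc1)c1ccc2ccccc2c1` has not yet been measured in this assay; it differs from compound 1 by 2-phenylethynyl in place of 2-phenylethenyl on a carbonyl carbon, the same change as the one from compound 3 to compound 2. For compound 4 the expected step is a number 4 percentage points lower from compound 1 to compound 4 (within the scatter), resting on the earlier step of a number 4 percentage points lower from compound 3 to compound 2 (within the scatter). Compound 4 is therefore estimated at 112%, expected to fall between 98% and 126%.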

Compound 4, largest response reached (reported as efficacy), in percent of the reference or control that the assay uses: 115%
Compound 4: the middle estimate sits 3 percentage points below what was measured; the range from low to high includes it.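

In this assay, 2-phenylethynyl in place of 2-phenylethenyl on a carbonyl carbon gave a number 1 percentage points lower from compound 1 to compound 4 (within the scatter). Set beside the earlier step, the change reads alike on the two cores: the same change on two cores in this assay, a number 4 percentage points lower (within the scatter) from compound 3 to compound 2 and a number 1 percentage points lower (within the scatter) from compound 1 to compound 4, 3 percentage points apart, within the scatter of two such steps. This shows that the swap left the maximal response within the scatter on both cores, but it does not show that the same would hold on any other core, and it says nothing about potency, as only the largest response is given here. The compounds shown leave open how a saturated 2-phenylethyl chain or a plain methyl on the carbonyl carbon would read. They also leave open what a primary amine in place of the dimethylamino group would do.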